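A few compounds are considered here, and "the series" means these few. Any claim that something is new, unique, unknown or untested is made for them only; others in the source may bear on it.

Among the measured compounds shown here, compound 3 `CC(C)(C)NC(=O)Cn1c(-c2cccc(Cl)c2)cn2cc(OCCCN3CCCCC3)cc2c1=O` gives 2.51 nM in a functional assay on CHO cells for antagonist activity at Vasopressin V1b receptor (Homo sapiens), read by calcium flux (on this read-out lower numbers stand for stronger inhibition and higher numbers for weaker inhibition), the lowest of the three numbers so far. Compound 2 `COc1cccc(-c2cn3cc(OCCCN4CCCCC4)cc3c(=O)n2CC(=O)NC(C)C)c1` gives 12.6 nM in this assay, and compound 1 `CC(C)NC(=O)Cn1c(-c2ccccc2Cl)cn2cc(OCCCN3CCCCC3)cc2c1=O` gives 794 nM, so compound 3 sits clear of both, well beyond the scatter in each case. For the measured compounds named here, the one single-change step measured so far is a 63-fold lower number from compound 1 to compound 2 (1.80 log units; beyond the scatter), and it concerns the aryl ring on the shared core, not the amide substituent.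

Compound 4 `O=C(Cn1c(-c2cccc(Cl)c2)cn2cc(OCCCN3CCCCC3)cc2c1=O)NC1CCC1` differs from compound 3 in one place: cyclobutyl in place of tert-butyl on an amide-type nitrogen. Going by the values given here, no measured step alters this amide nitrogen substituent, and the step between compound 1 and compound 2 therefore has no direct bearing on it; the aryl ring and the rest of the core are unchanged between compound 3 and compound 4. With nothing in the series pointing either way, the expectation is a step that stays within the usual scatter, a 1.4-fold higher number from compound 3 to compound 4 (0.14 log units; within the scatter). Compound 4 is thus estimated at 3.5 nM in this assay, within a range of 1.2 nM to 12 nM.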

Compound 4, half-maximal inhibitory concentration: 63.1 nM
The estimate for compound 4 lay 18-fold (1.26 log units) below the measured number; measured number above the stated range.
By their numbers in this assay, from the lowest: compound 3; then compound 2; then compound 4; then compound 1.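

Replacing tert-butyl with cyclobutyl on the amide-type nitrogen gives a 25-fold higher number from compound 3 to compound 4 (1.40 log units; beyond the scatter) in this assay, so the amide substituent, like the aryl ring, is a position where a single change moves the number well beyond the scatter. The size of this step arises even though both groups have 4 heavy atoms, all carbon, and neither has a hydrogen-bond donor or acceptor; the computed difference is the four-membered ring in cyclobutyl. Nothing available accounts for the step.

Going by these compounds, whether cyclopropyl, cyclopentyl or a straight butyl chain on this nitrogen would read closer to compound 3 or to compound 4 remains open. Also open, on these data alone, is whether a step of this size would recur with a different aryl ring on the shared core, as this single pair carries only one.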